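Swapping the aryl group in a weakly active series

The compounds below may be only part of what the source reports. "The series", "measured", "known", "first", "only" and "open" are said of these compounds alone.

Compound 1 `CCOc1ccc(-c2cc(=O)c3c(o2)C(CC)(CC)C(=O)C(CC)=C3O)cc1` carries a 4-ethoxyphenyl group on the shared core. In a functional assay on KB cells (Homo sapiens) for antiproliferative activity, read by sulforhodamine B assay, with a stated time of 3 days (a lower number here means that less compound is needed, a higher number that more compound is needed for the effect), compound 1 gives only a limit, > 52.4 uM. Two related compounds have been measured alongside it. Compound 2 `CCC1=C(O)c2c(oc(-c3ccc(CBr)cc3)cc2=O)C(CC)(CC)C1=O` also gives only a limit in this assay, > 46.5 uM. Among the compounds with values here, compound 3 `CCC1=C(O)c2c(oc(-c3ccc(C)c(C)c3)cc2=O)C(CC)(CC)C1=O` gives 35.5 uM in this assay, the one number among the three. Compound 1 thus stands at a limit rather than at a number: the step that the two limits leave unreadable from compound 1 to compound 2 cannot be read, and the step of an at least 1.4-fold lower number from compound 1 to compound 3 (0.16 log units; that floor lies within the scatter) has a floor that lies within the scatter. The step of an at least 1.3-fold lower number from compound 2 to compound 3 (0.11 log units; that floor lies within the scatter) likewise has a floor within the scatter.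

Compound 4 `CCC1=C(O)c2c(oc(-c3ccc(OC)c(F)c3)cc2=O)C(CC)(CC)C1=O` has not yet been measured. It differs from compound 1 in one place: 3-fluoro-4-methoxyphenyl in place of 4-ethoxyphenyl on an aromatic carbon. Within the data shown here, the only readable neighbour, the step from compound 1 to compound 3, shows that another aryl change produced a number close to the limit. Among the measured compounds shown here, nothing among the measured steps points to a large move in this assay; a small lowering, or no step beyond the scatter, is expected. Compound 4 is therefore estimated to give about 45 uM in this assay, within 20 uM to 100 uM, which means an expected step of an at least 1.1-fold lower number from compound 1 to compound 4 (0.06 log units; that floor lies within the scatter).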

Compound 4, concentration for half-maximal effect: 26.7 uM
Estimate against measurement, compound 4: 1.7-fold (0.23 log units) above; the measured number falls inside the stated range.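

With compound 4, the 3-fluoro-4-methoxyphenyl group on the aromatic carbon next to the ring oxygen gives a second number rather than a limit in this assay, so this position now has one step between two numbers, a 1.3-fold lower number from compound 3 to compound 4 (0.12 log units; within the scatter), and that step does not separate the two aryl groups. The step of an at least 1.9-fold lower number from compound 1 to compound 4 (0.29 log units; that floor lies within the scatter) remains only a floor, because compound 1 stands at a limit: the limit of > 52.4 uM in this assay, at which 1 of the 4 values shown sits. The step of an at least 1.7-fold lower number from compound 2 to compound 4 (0.24 log units; that floor lies within the scatter) is likewise only a floor, because compound 2 also stands at a limit: the limit of > 46.5 uM in this assay, at which 1 of the 4 values shown sits.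

The compounds shown leave open which part of the 3-fluoro-4-methoxyphenyl group matters, as the fluorine and the methoxy arrive together here, and whether any aryl group at this position can move the number beyond the scatter. They also do not show how an amine or a carboxylic acid on this aryl ring would read in this assay.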